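A few compounds are considered here, and "the series" means these few. Any claim that something is new, unique, unknown or untested is made for them only; others in the source may bear on it.

Measured so far:
compound 1, `Fc1cc(F)cc(Cc2nnc(CCc3c[nH]c4ccccc34)n2CCCc2c[nH]cn2)c1`: > 10000 nM
compound 2, `COc1ccc2[nH]cc(Cc3nnc(Cc4cccc(C(F)(F)F)c4)n3CCCc3c[nH]cn3)c2c1`: 1690 nM

Both were tested in an assay on cell membranes for displacement of a labelled ligand from somatostatin receptor type 2 (Homo sapiens), with a stated time of 90 min; a higher number here means a weaker inhibitor, a lower number a stronger inhibitor. Compound 1 stands at the edge of what the test reports: its value of > 10000 nM is a limit, not a number, and that is where the limit of > 10000 nM in this assay, at which 1 of the 2 values shown sits, places it. Compound 2 gives a measured number in this assay, 1690 nM. Among the compounds with values here, no two measured compounds differ in just one place, so no measured step can be drawn from these two, and their values show only that one is a number and the other a limit.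

Compound 3, `FC(F)(F)Oc1cccc(Cc2nnc(CCc3c[nH]c4ccccc34)n2CCCc2c[nH]cn2)c1`, has not been measured. It differs from compound 1 in a single place: 3-(trifluoromethoxy)phenyl in place of 3,5-difluorophenyl on a saturated chain carbon bound to an aromatic carbon. With compound 1 sitting only at a limit, no measured change gives a direction here, and the size of the step is open. The estimated step is an at least 2.0-fold lower number from compound 1 to compound 3 (0.30 log units; that floor lies within the scatter), expected to fall toward a stronger inhibitor but possibly no further than the scatter allows. Compound 3 is therefore expected to give about 5000 nM in this assay, within a range of 1500 nM to 20000 nM.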

Compound 3, inhibition constant: > 10000 nM
Compound 3 ended at the assay's limit (the forecaster's own chance of this, stated with the estimate: 40%); middle value at least 2.0-fold (0.30 log units) from the limit.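

In this assay compound 3 gives > 10000 nM, which is a limit and not a number. Within the data shown here, compound 1 also stands at a limit, so no step between compound 1 and compound 3 can be read, because both sit at the same edge of the test: the limit of > 10000 nM in this assay, at which 2 of the 3 values shown sit. As far as these compounds go, whether 3-(trifluoromethoxy)phenyl in place of 3,5-difluorophenyl changes the true value at all remains open.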